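The source may hold more compounds than are shown below. What is called first, only, known or untested is meant among the compounds shown, and "the series" means these compounds.

In a functional assay on COLO 205 cells (Homo sapiens) for inhibition, read by sulforhodamine B assay (a lower number here means a stronger inhibitor of growth, a higher number a weaker inhibitor of growth), compound 1 `FC(F)(F)c1ccc(-c2ccc(-c3ccc(-c4nc5ccccc5[nH]4)cc3)cc2)cc1` gives 33900 nM. Compound 2 `Oc1cccc2[nH]c(-c3ccc(-c4ccc(-c5ccc(C(F)(F)F)cc5)cc4)cc3)nc12` gives 3410 nM, the lower of the two numbers. Placing hydroxy in place of hydrogen on an aromatic carbon accounts for the structural difference behind a 9.9-fold lower number from compound 1 to compound 2 (1.00 log units; beyond the scatter). Compound 3 `Oc1cccc2[nH]c(-c3ccc(-c4ccc(-c5cccc(Cl)c5)cc4)cc3)nc12` keeps that hydroxy and differs from compound 2 elsewhere: 3-chlorophenyl in place of 4-(trifluoromethyl)phenyl on an aromatic carbon. For the measured compounds named here, the only measured step concerns the hydroxy, so no measured step bears directly on this swap, and no change beyond the scatter is expected in this assay. The expected result is a 1.1-fold lower number from compound 2 to compound 3 (0.06 log units; within the scatter). Compound 3 is estimated at 3000 nM, with an expected range of 1000 nM to 9000 nM.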

Compound 3, concentration for 50% growth inhibition: 8600 nM
Estimate against measurement, compound 3: 2.9-fold (0.46 log units) below, and the stated range covers the measured number.
By their numbers in this assay, from the lowest: compound 2; then compound 3; then compound 1.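

In this assay, the outer ring of the molecule also affects the result, not just the hydroxy: 3-chlorophenyl in place of 4-(trifluoromethyl)phenyl gives a 2.5-fold higher number from compound 2 to compound 3 (0.40 log units; beyond the scatter). This swap alters both the substituent and its place on the ring, so a single step cannot separate those two changes. Nothing available here explains the step. Still open, going by these compounds, is whether 4-chlorophenyl would behave like 3-chlorophenyl or 4-(trifluoromethyl)phenyl. Also open, on these data alone, is how an amine or a carboxylic acid on this ring would change the number.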